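Ring size at the chain carbon and liver clearance

The source may report more compounds than this note shows. Statements on the series, on what has been measured and on what is new or still open speak of the compounds shown alone.

Measured values in an ADME assay on microsomes from liver (Mus musculus, strain NMRI) for metabolic stability, tested at 2.5 uM; a higher number here means faster removal of the compound, a lower number slower removal:
compound 1 `Clc1ccc(Cn2nnc3c(Br)cccc32)cc1` gives 2 mL/min/g
compound 2 `Brc1cccc2c1nnn2CC1CCCC1` gives 11.4 mL/min/g
compound 3 `Brc1cccc2c1nnn2CC1CCC1` gives 11.4 mL/min/g

Compound 3 stands level with compound 2 at the digits shown, and together the two carry the highest numbers of the three; compound 1 lies a good deal lower, beyond the scatter. Compound 4 `Brc1cccc2c1nnn2CC1CC1` is not yet measured. The change from compound 3 to compound 4 is cyclopropyl in place of cyclobutyl on a saturated chain carbon bound to an aromatic nitrogen. Within the data shown here, the one measured step that bears on it is the earlier change of ring at the same place, no change at the digits printed from compound 2 to compound 3 (within the scatter), which left the number where it was. The shared core is untouched and only the ring on the saturated chain carbon bound to an aromatic nitrogen is exchanged again, so no step beyond the scatter is expected in this assay in either direction. Compound 4 is therefore estimated at about 10 mL/min/g, within 5 mL/min/g to 20 mL/min/g. The expected step is a 1.1-fold lower number from compound 3 to compound 4 (0.06 log units; within the scatter).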

Compound 4, intrinsic clearance in a liver preparation (reported as CLH), per the amount of preparation that the assay uses: 7.7 mL/min/g
The estimate for compound 4 lay 1.3-fold (0.11 log units) above the measured number, within the range that was stated.
By their numbers in this assay, from the lowest: compound 1; then compounds 4, 2 and 3 (each within the scatter of the next).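

In this assay, a 1.5-fold lower number from compound 3 to compound 4 (0.17 log units; within the scatter) follows cyclopropyl in place of cyclobutyl on a saturated chain carbon bound to an aromatic nitrogen, and a 1.5-fold lower number from compound 2 to compound 4 (0.17 log units; within the scatter) follows cyclopropyl in place of cyclopentyl. Among these compounds, with the cyclopropyl ring included, no step among the cyclopentyl, cyclobutyl and cyclopropyl compounds lies beyond the scatter, so these three rings do not separate the compounds at this place in this assay. No measurement bears on what lies behind these numbers.

From the compounds shown here alone, whether any group at this place moves the number beyond the scatter remains open, for example a longer chain, an amine or a carboxylic acid. Going by these compounds, it is also open whether the flat result across these three rings would hold with a group other than bromine on the shared core.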